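The source may report more compounds than this note shows. Statements on the series, on what has been measured and on what is new or still open speak of the compounds shown alone.

Values in a functional assay (aorta) with Rattus norvegicus as the target; on this read-out lower numbers stand for lower potency and higher numbers for higher potency (the scale is a negative logarithm):
compound 1 `CC1(C)C=C(n2ccccc2=O)c2ccccc2O1` gives 5.43
compound 2 `CCC(=O)c1ccc2c(c1)C(n1ccccc1=O)=CC(C)(C)O2` gives 6.63
compound 3 `COc1ccc(C(=O)c2ccc3c(c2)C(n2ccccc2=O)=CC(C)(C)O3)cc1` gives 6.15

Compound 3 stands second highest of the three: the step of a number 0.48 log units lower from compound 2 to compound 3 (beyond the scatter) places it below compound 2, and compound 1 lies lower still, the gap beyond the scatter. Compound 4 `CC1(C)C=C(n2ccccc2=O)c2cc(C(=O)c3ccco3)ccc2O1` differs from compound 3 by furan-2-yl in place of 4-methoxyphenyl on a carbonyl carbon. Among the compounds with values here, no measured step exchanges one aryl for another on that carbonyl carbon. Within the data shown here, two steps bear on it indirectly: a number 1.20 log units higher from compound 1 to compound 2 (beyond the scatter) shows a large gain once a carbonyl group sits on the aromatic carbon at all, and a number 0.48 log units lower from compound 2 to compound 3 (beyond the scatter) shows a modest loss when 4-methoxyphenyl replaces ethyl there. Furan-2-yl may fall between ethyl and 4-methoxyphenyl, so the expected step is a number 0.20 log units higher from compound 3 to compound 4 (within the scatter), small and upward if anything. Compound 4 is estimated at 6.35, with a range of 5.85 to 6.85.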

Compound 4, logarithm of the reciprocal of the active concentration, log(1/C): 6.49
Beside the measured number, compound 4's estimate is 0.14 log units below it, within the range that was stated.
By their numbers in this assay, from the lowest: compound 1; then compound 3; then compounds 4 and 2 (each within the scatter of the next).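

In this assay, exchanging one aromatic ring for another on this carbonyl carbon gives a number 0.34 log units higher from compound 3 to compound 4 (beyond the scatter), so the choice of ring matters here. The exchange of ethyl for furan-2-yl gives a number 0.14 log units lower from compound 2 to compound 4 (within the scatter), so the loss seen with 4-methoxyphenyl does not apply to every aromatic ring at this place. The gain from acylating the aromatic carbon also holds with (furan-2-yl)carbonyl, at a number 1.06 log units higher from compound 1 to compound 4 (beyond the scatter).

No available evidence explains the difference between the two rings. Going by these compounds, how unsubstituted phenyl, a longer chain or an amine would read on this carbonyl carbon stays open.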